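The source may report more compounds than this note shows. Statements on the series, on what has been measured and on what is new or still open speak of the compounds shown alone.

Measured so far:
compound 1, `COc1ccc(N2C(=O)N(Cc3c(F)cc(F)cc3F)c3ccccc3S2(=O)=O)cc1OC`, in an assay on HEK293 cells for displacement of a labelled ligand from Orexin receptor type 2 (Homo sapiens), read by scintillation counting, with a stated time of 90 min; on this read-out higher numbers stand for weaker inhibition and lower numbers for stronger inhibition: 2 nM
compound 2, `COc1ccc(N2C(=O)N(Cc3ccccc3)c3ccccc3S2(=O)=O)cc1OC`, in this assay: 79.4 nM

On these two numbers compound 1 stands lowest. Among the measured compounds shown here, the only measured step, a 40-fold higher number from compound 1 to compound 2 (1.60 log units; beyond the scatter), concerns the 2,4,6-trifluorobenzyl group, which compound 3, `COc1cc(N2C(=O)N(Cc3c(F)cc(F)cc3F)c3ccccc3S2(=O)=O)cc(OC)n1`, keeps unchanged. Compound 3 instead differs from compound 1 by 2,6-dimethoxypyridin-4-yl in place of 3,4-dimethoxyphenyl on an amide-type nitrogen in a ring. For the measured compounds named here, no measured step touches this part of the shared core, so the direction of any change is unknown, and a step within the scatter is expected in this assay. Compound 3 is therefore estimated to give 4 nM, with a range from 1 nM to 20 nM. This estimate means an expected step of a 2.0-fold higher number from compound 1 to compound 3 (0.30 log units; within the scatter).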

Compound 3, inhibition constant: 1.26 nM
For compound 3 the middle estimate is 3.2-fold (0.50 log units) above the measured one; the range from low to high includes it.
By their numbers in this assay, from the lowest: compounds 3 and 1 (each within the scatter of the next); then compound 2.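

Putting 2,6-dimethoxypyridin-4-yl in place of 3,4-dimethoxyphenyl on this amide-type nitrogen gives a 1.6-fold lower number from compound 1 to compound 3 (0.20 log units; within the scatter) in this assay. This position therefore accepts a ring with one hetero atom, and a count of 3 hydrogen-bond acceptors rather than 2, with no step beyond the scatter. No measurement here offers an explanation for this result.

Still open, from the compounds shown here alone, is whether this position would accept a ring carrying an amine or a carboxylic acid in place of the methoxy groups. Going by these compounds, the large step seen on removing the fluorines also remains untested alongside 2,6-dimethoxypyridin-4-yl.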